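The source may report more compounds than this note shows. Statements on the series, on what has been measured and on what is new or still open speak of the compounds shown alone.

Compound 1 `CC(C)[C@@H](CO)n1cc(C(=O)O)c(=O)c2cc(Cc3cccc(Cl)c3F)ncc21` gives 100%
Compound 2 `CC(C)[C@@H](CO)n1cc(C(=O)O)c(=O)c2nc(Cc3cccc(Cl)c3F)ccc21` gives "not determined" (no result reported)
Compound 3 `CC[C@@H](CO)n1cc(C(=O)O)c(=O)c2cc(Cc3cccc(Cl)c3F)c(OC)nc21` gives "not determined" (no result reported)

In an ADME assay on microsomes from liver (Homo sapiens) for metabolic stability, with a stated time of 30 min (a higher number here means that more of the compound is left, a lower number that less of the compound is left), only compound 1 has a number. Compound 3 stands without a single value, as does compound 2. Compound 4 `COc1nc2c(cc1Cc1cccc(Cl)c1F)c(=O)c(C(=O)O)cn2[C@H](CO)C(C)(C)C` has yet to be measured. Its structure departs from that of the ethyl compound through tert-butyl in place of ethyl on a saturated chain carbon bound to an aromatic nitrogen and a saturated chain carbon with tert-butyl in place of ethyl on a saturated chain carbon bound to an aromatic nitrogen and a saturated chain carbon. Going by the values given here, no measured step shows what such a change does. A modest downward step is expected, possibly none beyond the scatter, and compound 1 at 100% is the sole reference. For compound 4 in this assay the estimated value is 80% with an expected range from 55% to 100% for a single measurement.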

Compound 4, percent of the compound remaining: 82%
Compound 4: the middle estimate sits 2 percentage points below what was measured, within the range that was stated.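

No step can be read between compound 3 and compound 4 in this assay as compound 3 has no single number. On these data alone, what tert-butyl in place of ethyl does there stays open, and no further data at hand bear on the result.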